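This account rests on a few compounds, and the source may have more. Where it says the series, first, only, none or still open, it means among the compounds named here.

Of the compounds shown here, two sharing one core have been measured in a functional assay on ZR-75-1 cells (Homo sapiens) for inhibition, read by sulforhodamine B assay; on this read-out higher numbers stand for weaker inhibition of growth and lower numbers for stronger inhibition of growth. Compound 1 `Oc1cccc2[nH]c(-c3ccc(-c4ccc(-c5ccccc5)cc4)cc3)nc12` gives 35600 nM, and compound 2 `Oc1ccc(-c2ccc(-c3ccc(-c4nc5c(O)cccc5[nH]4)cc3)cc2)cc1` gives 2650 nM. Among the measured compounds shown here, the single measured step, a 13-fold lower number from compound 1 to compound 2 (1.13 log units; beyond the scatter), shows that a change at the far end of the terminal ring can move the number a long way. For the measured compounds named here, compound 2 thus stands at the lower of the two values, with compound 1 the only neighbour and well apart from it.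

Compound 3 `CN(C)c1ccc(-c2ccc(-c3ccc(-c4nc5c(O)cccc5[nH]4)cc3)cc2)cc1` is the next step: dimethylamino in place of hydroxy on an aromatic carbon, which read one bond further out is 4-hydroxyphenyl to 4-(dimethylamino)phenyl. Going by the values given here, only the step from compound 1 to compound 2 bears on it, and only loosely, since it tells what a hydroxy adds there, not what a dimethylamino does in its stead. One hydrogen-bond acceptor remains while the donor leaves, so the gain seen in compound 2 need not be kept in full. A moderate rise in the number, beyond the scatter, is expected, a 1.9-fold higher number from compound 2 to compound 3 (0.28 log units; within the scatter), and compound 3 is estimated at 5000 nM with a range from 1300 nM to 18000 nM.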

Compound 3, concentration for 50% growth inhibition: 4100 nM
The estimate for compound 3 lay 1.2-fold (0.09 log units) above the measured number; measured number inside the range.
By their numbers in this assay, from the lowest: compounds 2 and 3 (each within the scatter of the next); then compound 1.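

In this assay, exchanging hydroxy for dimethylamino on this aromatic carbon gives a 1.5-fold higher number from compound 2 to compound 3 (0.19 log units; within the scatter) and so leaves the two compounds level within the scatter, even though the entering group carries 0 hydrogen-bond donors and 3 heavy atoms in place of 1. Measured against the compound with only hydrogen at this place, dimethylamino gives an 8.7-fold lower number from compound 1 to compound 3 (0.94 log units; beyond the scatter) in the same assay, so the drop in the number seen with hydroxy is not particular to hydroxy, and the hydrogen-bond donor of that group is not needed for it among these three compounds. Nothing available explains why these two different groups read alike here.

Going by these compounds, whether a methoxy, a primary amine or a carboxylic acid at this place would match hydroxy and dimethylamino remains open, so it cannot yet be said how widely the place tolerates change. Also open, on these data alone, is whether a hydroxy or dimethylamino group elsewhere on the same ring would hold the number at this level.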